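The compounds below may be only part of what the source reports. "The series", "measured", "known", "first", "only" and "open" are said of these compounds alone.

Values in a physicochemical assay for solubility, read by LC-MS, in phosphate buffer, with a stated time of 24 h, at pH 7.4 (on this read-out higher numbers stand for higher solubility and lower numbers for lower solubility), all three of them limits:
- compound 1 `CC(=O)N1CCC(c2cnc(NCc3c(F)ccc4c3CCO4)c3cn[nH]c(=O)c23)CC1`: < 2000 nM
- compound 2 `Cc1nc(CN(C)C)ccc1-c1cnc(NCc2c(F)ccc3c2CCO3)c2cn[nH]c(=O)c12`: > 1000000 nM
- compound 3 `Cc1ncccc1-c1cnc(NCc2c(F)ccc3c2CCO3)c2cn[nH]c(=O)c12`: < 2000 nM

Compound 3 sits at the limit of < 2000 nM in this assay, at which 2 of the 3 values shown sit, so its position is a limit and not a number. Among the compounds with values here, compound 2 alone sits at the limit of > 1000000 nM in this assay, at which 1 of the 3 values shown sits, and it is the only measured compound carrying (dimethylamino)methyl.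

The next change gives compound 4 `Cc1nn(C)cc1-c1cnc(NCc2c(F)ccc3c2CCO3)c2cn[nH]c(=O)c12`, with 1,3-dimethyl-1H-pyrazol-4-yl in place of 2-methylpyridin-3-yl on an aromatic carbon.

The clearest measured change at this position is an at least 500-fold higher number from compound 1 to compound 2 (2.69 log units; beyond the scatter), which is large. Equally large is an at least 500-fold lower number from compound 2 to compound 3 (2.69 log units; beyond the scatter), with hydrogen in place of (dimethylamino)methyl. Compound 4 also lacks that group, so neither large step transfers directly. The closest comparison, a step that the two limits leave unreadable from compound 1 to compound 3, exchanges one group without that side chain for another and gives no readable size.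

Within the data shown here, no large step is therefore expected in this assay, and any direction is tentative. The expected change is a step that the limit leaves unreadable from compound 3 to compound 4. For compound 4 the estimate is 1500 nM, with an expected range of 400 nM to 10000 nM.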

Compound 4, solubility: 9000 nM
For compound 4 the middle estimate is 6.0-fold (0.78 log units) below the measured one, within the range that was stated.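

In this assay, within the data shown here, 1,3-dimethyl-1H-pyrazol-4-yl gives the first reading at this position that is a number and not a limit, and it shows that a group without (dimethylamino)methyl can still shift the read-out: the change gives an at least 4.5-fold higher number from compound 3 to compound 4 (0.65 log units; beyond the scatter) and an at least 4.5-fold higher number from compound 1 to compound 4 (0.65 log units; beyond the scatter). Both steps are bounds and not full sizes, since compound 3 holds a limit, as does compound 1: the limit of < 2000 nM in this assay, at which 2 of the 4 values shown sit. The same group still leaves an at least 110-fold lower number from compound 2 to compound 4 (2.04 log units; beyond the scatter), and that step too is only a bound, since compound 2 holds the opposite limit: the limit of > 1000000 nM in this assay, at which 1 of the 4 values shown sits.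

Open, from the compounds shown here alone, is whether the large gap to compound 2 follows the (dimethylamino)methyl side chain or the ring that carries it. A 1,3-dimethyl-1H-pyrazol-4-yl bearing that side chain, or a 2-methylpyridin-3-yl bearing a morpholine or a carboxylic acid in its place, would separate the two.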